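Replacing the bromophenyl ring with a small nitrile group

A few compounds are considered here, and "the series" means these few. Any claim that something is new, unique, unknown or untested is made for them only; others in the source may bear on it.

Of the compounds shown here, two with a shared core have been tested in an ADME assay on MT4 cells (Homo sapiens) for cytotoxicity, read by MTT assay, with a stated time of 4 days; a higher number here means that more compound is tolerated, a lower number that less compound is tolerated. Compound 1 `O=C1c2sccc2N(Cc2ccc(Cl)cc2Cl)S(=O)(=O)N1Cc1ccccc1` gives 247000 nM, and compound 2 `O=C1c2sccc2N(Cc2ccc(Br)cc2)S(=O)(=O)N1Cc1ccccc1` gives 6600 nM. Among the measured compounds shown here, compound 2 therefore stands at the lowest of the two numbers, meaning that cells tolerate less of it than of compound 1; the only step measured so far, a 37-fold lower number from compound 1 to compound 2 (1.57 log units; beyond the scatter), shows that swapping one substituted phenyl ring for another at this position can move the number a great deal.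

Compound 3 `N#CCN1c2ccsc2C(=O)N(Cc2ccccc2)S1(=O)=O` goes further in the same place: cyano in place of 4-bromophenyl on a saturated chain carbon bound to a sulfonamide nitrogen in a ring. For the measured compounds named here, no measured step covers the loss of the whole aromatic ring in favour of a nitrile, so the single step from compound 1 to compound 2 only tells how sensitive this position is, not which way a nitrile will turn out. With that uncertainty, compound 3 is expected to be tolerated somewhat better than compound 2, the expected step being a 9.1-fold higher number from compound 2 to compound 3 (0.96 log units; beyond the scatter). Compound 3 is estimated at 60000 nM, with a range from 12000 nM to 300000 nM.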

Compound 3, half-maximal cytotoxic concentration: 5700 nM
Beside the measured number, compound 3's estimate is 11-fold (1.02 log units) above it, outside the stated range (below it).
By their numbers in this assay, from the lowest: compounds 3 and 2 (each within the scatter of the next); then compound 1.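

In this assay, putting cyano in place of 4-bromophenyl on a saturated chain carbon bound to a sulfonamide nitrogen in a ring gives a 1.2-fold lower number from compound 2 to compound 3 (0.06 log units; within the scatter), so swapping 7 heavy atoms and an aromatic ring for 2 heavy atoms and no ring leaves the number within the scatter. Set against the 2,4-dichlorophenyl group, the same cyano gives a 43-fold lower number from compound 1 to compound 3 (1.64 log units; beyond the scatter), so a phenyl ring at this place is not needed for a number like that of compound 2, and among these three compounds only compound 1 stands apart, at a much higher number. The data shown offer no measurement that would explain either result.

What the compounds shown leave open is which feature of the 2,4-dichlorophenyl group goes with the high number of compound 1, since a plain phenyl or a 4-chlorophenyl group would help separate the role of each chlorine from that of the ring. From the compounds shown here alone, it also remains open whether other small groups at this place, such as an amine, a carboxylic acid or a longer carbon chain, would stay close to compound 3 or move as far as compound 1.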